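Adding a methyl to the chain amine of a curcumin-like enaminone

The source may hold more compounds than are shown below. What is called first, only, known or untested is meant among the compounds shown, and "the series" means these compounds.

The series is built on a shared core, exemplified by compound 1 `CCCNC(=C\C(=O)/C=C/c1ccc(O)c(OC)c1)/C=C/c1ccc(O)c(OC)c1`, an enaminone bearing two hydroxy-methoxyphenyl arms and a propylamino group. In a functional assay on CHO-K1 cells (Cricetulus griseus) for inhibition, read by MTT assay, with a stated time of 72 h (a lower number here means a stronger inhibitor, a higher number a weaker inhibitor), compound 1 gives only a limit, > 25000 nM, and not a number. Compound 3 `CC(=O)Oc1ccc(/C=C/C(=O)/C=C(/C=C/c2ccc(OC(C)=O)cc2)NCC(C)C)cc1` likewise reaches only a limit in this assay, > 25000 nM. Compound 2 `CCC(C)NC(=C\C(=O)/C=C/c1ccc(O)cc1)/C=C/c1ccc(O)cc1`, by contrast, gives a number in this assay, 13100 nM. Two of the three values thus sit at the same boundary, as the limit of > 25000 nM in this assay, at which 2 of the 3 values shown sit, records.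

Compound 4 `COc1cc(/C=C/C(=O)/C=C(/C=C/c2ccc(O)c(OC)c2)NCC(C)C)ccc1O` differs from compound 1 in one place: methyl in place of hydrogen on a saturated chain carbon bound to two saturated chain carbons. The added methyl leaves the arms untouched and changes propylamino to isobutylamino. With compound 1 already at a limit, the step is expected to be small or absent beyond the scatter, and the estimated step that the limit leaves unreadable from compound 1 to compound 4 leaves compound 4 near the same boundary. Compound 4 is therefore estimated at 30000 nM in this assay, with a plausible range from 10000 nM to 100000 nM, and a strong chance that only a limit is reported.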

Compound 4, half-maximal inhibitory concentration: > 25000 nM
Compound 4 was reported as a limit; the forecaster's own chance of this, stated with the estimate: 70%; the middle value does not contradict the limit.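

Compound 1 and compound 4 both stand only as limits in this assay, and no step can be read between them. The compounds shown leave open whether the change from propylamino to isobutylamino alters inhibition at all.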